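From compound 2 to compound 4: toxicity at the limit

A few compounds are considered here, and "the series" means these few. Any claim that something is new, unique, unknown or untested is made for them only; others in the source may bear on it.

Measured so far in a functional assay on C8166 cells (Homo sapiens) for antiproliferative activity, read by MTT assay (on this read-out lower numbers stand for higher toxicity in this test and higher numbers for lower toxicity in this test), and each entry a limit of the assay:
compound 1 `Cc1cc(C)cc(S(=O)(=O)c2c(C(=O)NCC(=O)NN)[nH]c3ccc(Cl)cc23)c1` gives > 100 uM (a limit)
compound 2 `Cc1cc(C)cc(S(=O)(=O)c2c(C(=O)NN3CCOC3=O)[nH]c3ccc(Cl)cc23)c1` gives > 100 uM (a limit)
compound 3 `Cc1cc(C)cc(S(=O)(=O)c2c(C(=O)NNC(C)C)[nH]c3ccc(Cl)cc23)c1` gives > 100 uM (a limit)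

In this assay compound 2 gives > 100 uM as a limit of the assay and not as a number. Among the compounds with values here, the whole series stands at the limit of > 100 uM in this assay, at which 3 of the 3 values shown sit, and no compound goes against that.

Compound 4 `CCOC(=O)NNC(=O)c1[nH]c2ccc(Cl)cc2c1S(=O)(=O)c1cc(C)cc(C)c1` differs from compound 2 in one group ((ethoxycarbonyl)amino in place of 2-oxo-1,3-oxazolidin-3-yl on an amide-type nitrogen). In short, (ethoxycarbonyl)amino stands in place of 2-oxo-1,3-oxazolidin-3-yl on an amide-type nitrogen.

Within the data shown here, three measured steps bear on this change at that nitrogen. They read a step that the two limits leave unreadable from compound 1 to compound 2 and a step that the two limits leave unreadable from compound 1 to compound 3 and also a step that the two limits leave unreadable from compound 2 to compound 3 with no size to take from any of them. On these steps, which include compound 2, no step beyond the scatter is expected in this assay and no direction can be given. The estimate means a step that the limit leaves unreadable from compound 2 to compound 4 as the expected step, and a further report as a limit is the likeliest outcome. Compound 4 is expected at 120 uM with an estimated range from 60 uM to 200 uM on this read-out.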

Compound 4, half-maximal toxic concentration: > 100 uM
Compound 4 ended at the assay's limit; the forecaster's own chance of this, stated with the estimate: 80%; the middle value is on the limit's open side.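

In this assay compound 4 gives > 100 uM, which is a limit of the assay and not a number. No step to compound 4 from compound 1, compound 2 or compound 3 can be read, and the series stays at one limit: the limit of > 100 uM in this assay, at which 4 of the 4 values shown sit.

The compounds shown leave open whether any change on the amide-type nitrogen would bring a readable value on this read-out.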